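From Chloro to Methoxy on the Shared Core

This account rests on a few compounds, and the source may have more. Where it says the series, first, only, none or still open, it means among the compounds named here.

Of the compounds shown here, two have so far been measured in a functional assay on the whole organism with Rattus norvegicus as the target, at a dose of 10 mg/kg by the oral route; a lower number here means a weaker effect, a higher number a stronger effect of the compound at the dose given. Compound 1 `Cc1ccccc1-c1cc(Cl)cc(C(=O)Nc2nn[nH]n2)n1` gives 24% in this assay. Compound 2 `O=C(Nc1nn[nH]n1)c1cc(Cl)cc(-c2ccc([N+](=O)[O-])cc2)n1` gives 48%, the higher of the two numbers; its nearest neighbour, compound 1, lies a distance below it that exceeds the usual scatter. Since the two differ in more than one place, nothing more can be read from their pair than these two values.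

The next compound, compound 3 `COc1cc(C(=O)Nc2nn[nH]n2)nc(-c2ccc([N+](=O)[O-])cc2)c1`, has not yet been measured. It differs from compound 2 in one place: methoxy in place of chloro on an aromatic carbon on an aromatic carbon of a six-membered aromatic ring with 1 nitrogen, opposite the ring nitrogen.

Within the data shown here, no measured pair shows what such a change does in this assay, so its size is unknown. The exchange is small in atoms, and the remainder of compound 2 is kept, so the step from compound 2 to compound 3 is expected to stay within the scatter or fall slightly, a number 8 percentage points lower from compound 2 to compound 3 (within the scatter). On that basis compound 3 is estimated at 40%, with a range from 15% to 65%.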

Compound 3, a percentage reported as inhibition, in the whole organism at one dose (the size of the read-out at that dose, not a potency): 6%
Compound 3: middle estimate off by 34 percentage points, on the high side, and the stated range ends above it.
By their numbers in this assay, from the lowest: compound 3; then compound 1; then compound 2.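

In this assay, among these compounds, the exchange of chloro for methoxy, on an aromatic carbon opposite the ring nitrogen, gives a number 42 percentage points lower from compound 2 to compound 3 (beyond the scatter) and so provides the first reading of a change at this position, which the pair of compound 1 and compound 2 could not supply. The position is therefore not indifferent to what it carries: with the remainder of compound 2 kept, replacing one chlorine atom with a methoxy group of two heavy atoms and one hydrogen-bond acceptor is enough to move the read-out far beyond the usual scatter. Nothing measured here bears on why the number falls.

As far as these compounds go, a single step cannot separate the loss of chloro from the arrival of methoxy, so it remains open how a plain hydrogen, a fluorine, an amine or a longer chain such as ethoxy would fare at this position. Among the compounds shown here, it also remains open whether the same exchange would have a step of similar size with the other aromatic group of compound 1 in place of the one in compound 2, and, as this is a read-out at one dose, whether the weaker effect of compound 3 would hold at other doses.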